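The source may report more compounds than this note shows. Statements on the series, on what has been measured and on what is new or still open speak of the compounds shown alone.

Measured in an ADME assay on microsomes from liver (Mus musculus) for metabolic stability, read by LC-MS, with a stated time of 40 min, tested at 0.5 uM; on this read-out higher numbers stand for fast clearance and lower numbers for slow clearance:
- compound 1 `CC(C)S(=O)(=O)c1cccc(NC(=O)c2cccnc2N2CCC3(CC2)CC3)c1` gives > 399 mL.min-1.g-1 (a limit)
- compound 2 `CC(C)(C)NS(=O)(=O)c1cccc(NC(=O)c2ncc(NC(C)(C)CO)nc2N2CCC3(CC2)CC3)c1` gives 76 mL.min-1.g-1
- compound 3 `O=C(Nc1cccc(S(=O)(=O)N2CCCCC2)c1)c1cn[nH]c1-c1ccc(Cl)cc1` gives > 399 mL.min-1.g-1 (a limit)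

In this assay compound 1 stands at > 399 mL.min-1.g-1, which is a limit of the assay and not a number. Compound 2 alone returns a number.

Compound 4 `O=C(Nc1cccc(S(=O)(=O)N2CCCC2)c1)c1cccnc1N1CCC2(CC1)CC2` has not yet been measured. It departs from compound 1 by pyrrolidin-1-yl in place of isopropyl on a sulfonyl sulfur. Among the measured compounds shown here, no measured pair shows this change alone, so no step size can be read from the data. No step beyond the scatter is expected in this assay, and clearance is expected to remain fast. That expectation rests on compound 1 and compound 3, which sit at the limit of > 399 mL.min-1.g-1 in this assay, at which 2 of the 3 values shown sit. The expected step is an at least 1.3-fold lower number from compound 1 to compound 4 (0.12 log units; that floor lies within the scatter). For compound 4 the estimated clearance is 300 mL.min-1.g-1, with an expected range from 140 mL.min-1.g-1 to 399 mL.min-1.g-1.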

Compound 4, intrinsic clearance in microsomes: > 399 mL.min-1.g-1
Compound 4 gave a limit, no number (the forecaster's own chance of this, stated with the estimate: 45%); middle value at least 1.3-fold (0.12 log units) from the limit.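

In this assay, compound 1 and compound 4 both return only a limit of the assay and not a number, so no step can be read between them: the limit of > 399 mL.min-1.g-1 in this assay, at which 3 of the 4 values shown sit.

The compounds shown leave open whether pyrrolidin-1-yl in place of isopropyl on a sulfonyl sulfur changes clearance at all.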